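The source may report more compounds than this note shows. Statements on the series, on what has been measured and on what is new or still open speak of the compounds shown alone.

Measured so far in a functional assay on Cortical neurone cells (Mus musculus, strain C57BL/6), read by FLIPR and calcium flux, with a stated time of 8 min; a lower number here means a stronger inhibitor, a higher number a weaker inhibitor:
- compound 1 `Cc1ccc(Cc2nc3[nH]c(-c4ccc(Cl)cc4)cc(=O)n3n2)cc1` gives 5440 nM
- compound 2 `CCCCCCc1nc2[nH]c(-c3ccc(Cl)cc3)cc(=O)n2n1` gives 8720 nM

For the measured compounds named here, compound 1 has only one neighbour on this scale. The step of a 1.6-fold higher number from compound 1 to compound 2 (0.20 log units; within the scatter) is the only one measured, so neither compound can be ranked above the other.

Compound 3 `O=c1cc(-c2ccc(Cl)cc2)[nH]c2nc(-c3ccccc3)nn12` has not yet been measured. It keeps the core of compound 1 but carries phenyl in place of 4-methylbenzyl on an aromatic carbon. Going by the values given here, the one measured step also changed the substituent on this carbon of the core, which makes it the nearest available evidence. Among the compounds with values here, it is a limited guide, however: no measured compound carries phenyl on that aromatic carbon, and a single step cannot establish a trend.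

Within the data shown here, because a 1.6-fold higher number from compound 1 to compound 2 (0.20 log units; within the scatter) is the only guide, no step beyond the scatter is expected in this assay in either direction. The estimated step is a 1.2-fold higher number from compound 1 to compound 3 (0.08 log units; within the scatter) (an expectation only). For compound 3 the estimated value is 6500 nM with an expected range from 2500 nM to 17000 nM (an estimate, not a measurement).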

Compound 3, half-maximal inhibitory concentration: 2350 nM
Compound 3: the middle estimate sits 2.8-fold (0.44 log units) above what was measured; measured number below the stated range.
By their numbers in this assay, from the lowest: compound 3; then compounds 1 and 2 (each within the scatter of the next).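

In this assay the change to phenyl on the aromatic carbon between two ring nitrogen atoms moves the number beyond the scatter, whether 4-methylbenzyl leaves (a 2.3-fold lower number from compound 1 to compound 3 (0.36 log units; beyond the scatter)) or the hexyl chain leaves (a 3.7-fold lower number from compound 2 to compound 3 (0.57 log units; beyond the scatter)). The earlier pair, compound 1 and compound 2, stayed within the scatter of each other, so only now does this position prove responsive to what it carries. Both of those earlier groups reach the core through a saturated chain carbon, whereas the phenyl ring of compound 3 sits directly on the core, and this direct attachment goes with the lowest number of the three. No measurement shown here explains why the number falls.

Going from compound 1 to compound 3 removes both the methyl group and the linking carbon at once, so a plain benzyl group would be needed to show which of the two matters. Also open, on these data alone, is how this carbon would respond to a group of a different kind, such as an amine or a carboxylic acid, or to a substituent added to the phenyl ring itself.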